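The source may report more compounds than this note shows. Statements on the series, on what has been measured and on what is new or still open speak of the compounds shown alone.

In a functional assay on HT-29 cells (Homo sapiens) for inhibition, read by luminescence and CellTiter-Glo, with a stated time of 24 h (a lower number here means that less compound is needed, a higher number that more compound is needed for the effect), three compounds have been measured:

- Compound 1 `CC(C)n1nc(C(=O)N[C@H]2COc3ccccc3N(C)C2=S)nc1Cc1ccccc1`: 360 nM
- Compound 2 `CN1C(=S)[C@@H](NC(=O)c2nc(Cc3ccccc3)n(CCCF)n2)COc2ccccc21`: 4760 nM
- Compound 3 `CN1C(=S)[C@@H](NC(=O)c2nc(Cc3ccccc3)n(C3CCOCC3)n2)COc2ccccc21`: 2260 nM

These three differ only in the group on an aromatic nitrogen. Compound 3, the second highest of the three numbers, lies closer to compound 2 than to compound 1.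

The next compound, compound 4 `CN1C(=S)[C@@H](NC(=O)c2nc(Cc3ccccc3)n(C3CCNC3)n2)COc2ccccc21`, has pyrrolidin-3-yl in place of oxan-4-yl on an aromatic nitrogen.

Going by the values given here, three measured steps bear on this change. Replacing isopropyl cost potency both times, with a 13-fold higher number from compound 1 to compound 2 (1.12 log units; beyond the scatter) and a 6.3-fold higher number from compound 1 to compound 3 (0.80 log units; beyond the scatter). Exchanging the two replacement groups mattered much less, with a 2.1-fold lower number from compound 2 to compound 3 (0.32 log units; beyond the scatter). That smaller step is the closest guide, since it also starts from a group other than isopropyl. Among the compounds with values here, no measured compound carries pyrrolidin-3-yl, so the uncertainty is wide.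

The expected result in this assay is a small shift toward a higher number, possibly no step beyond the scatter. The estimate means a 1.5-fold higher number from compound 3 to compound 4 (0.19 log units; within the scatter). For compound 4, the estimated value is 3500 nM, with an expected range of 1000 nM to 12000 nM.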

Compound 4, half-maximal effective concentration: 1070 nM
Estimate against measurement, compound 4: 3.3-fold (0.51 log units) above, and the stated range covers the measured number.
By their numbers in this assay, from the lowest: compound 1; then compound 4; then compound 3; then compound 2.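

Pyrrolidin-3-yl is the only group here that carries a hydrogen-bond donor, and in this assay it gives a 2.1-fold lower number from compound 3 to compound 4 (0.32 log units; beyond the scatter) and a 4.4-fold lower number from compound 2 to compound 4 (0.65 log units; beyond the scatter) as well, so it ranks ahead of both other replacements at this position. Isopropyl still holds the lowest number, with a 3.0-fold higher number from compound 1 to compound 4 (0.47 log units; beyond the scatter) as the measured cost of the change, although that cost is the smallest of the three steps away from compound 1. Nothing measured here explains why the number moves with this change.

This change swaps the ring oxygen for a ring nitrogen and also shrinks the ring, so the two differences cannot be told apart. A cyclopentyl group, with the five-membered ring but no ring nitrogen, and a piperidin-4-yl group, with the ring nitrogen in a six-membered ring, would be needed to separate them.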